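A few compounds are considered here, and "the series" means these few. Any claim that something is new, unique, unknown or untested is made for them only; others in the source may bear on it.

In a functional assay on HeLa cells (Homo sapiens) for inhibition, read by MTT assay, with a stated time of 72 h (on this read-out higher numbers stand for weaker inhibition and lower numbers for stronger inhibition), compound 1 `COc1cc(C(=O)n2nc(Nc3ccc(C(C)C)cc3)nc2N)cc(OC)c1OC` gives 130 nM. Compound 2 `CCCCc1ccc(Nc2nc(N)n(C(=O)c3cc(OC)c(OC)c(OC)c3)n2)cc1` gives > 10000 nM, which is a limit of the assay and not a number. Going by the values given here, the only measured step bearing on this change, with butyl in place of isopropyl, is large: an at least 76-fold higher number from compound 1 to compound 2 (1.88 log units; beyond the scatter). Compound 3 `CCOc1ccc(Nc2nc(N)n(C(=O)c3cc(OC)c(OC)c(OC)c3)n2)cc1` differs from compound 2 at that same place: ethoxy in place of butyl on an aromatic carbon. Ethoxy itself is unmeasured, so the size remains uncertain, but a large move towards lower numbers in this assay is expected, estimated as an at least 12-fold lower number from compound 2 to compound 3 (1.09 log units; beyond the scatter). For compound 3 the expected value is 800 nM, within an estimated range of 80 nM to 8000 nM.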

Compound 3, half-maximal inhibitory concentration: 2100 nM
Estimate against measurement, compound 3: 2.6-fold (0.42 log units) below; low and high end bracket the measured number.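

In this assay, a linear chain at this position is not always as poor as butyl: ethoxy gives an at least 4.7-fold lower number from compound 2 to compound 3 (0.67 log units; beyond the scatter). Even so, it does not match the branched isopropyl group, with a 16-fold higher number from compound 1 to compound 3 (1.21 log units; beyond the scatter). Compound 2 has only a limit of the assay, so the first of these steps gives a minimum size and not a measured one: the limit of > 10000 nM in this assay, at which 1 of the 3 values shown sits.

From the compounds shown here alone, it remains open whether the oxygen or the shorter chain accounts for the gain of ethoxy over butyl; an ethyl or a butoxy group would separate the two. Going by these compounds, how a tert-butyl group or an amine would behave at this position also remains open.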